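The source may report more compounds than this note shows. Statements on the series, on what has been measured and on what is new or still open speak of the compounds shown alone.

Measured so far, in an assay on isolated protein for inhibition of malate dehydrogenase, mitochondrial (Sus scrofa), with stated times of 45 min and 30 min; on this read-out higher numbers stand for weaker inhibition and lower numbers for stronger inhibition:
- compound 1, `O=S(=O)(Nc1ccc2oc(-c3ccccc3)nc2c1)c1cccc(F)c1`: compound 1 gives > 63000 nM, a limit of the assay rather than a number.
- compound 2, `O=S(=O)(Nc1ccc(-c2nc3ccccc3o2)cc1)c1ccc(F)c(C(F)(F)F)c1`: compound 2 gives > 63000 nM, likewise a limit.
- compound 3, `O=S(=O)(Nc1ccc(-c2nc3ccccc3o2)cc1)c1cccs1`: compound 3 gives > 63000 nM, likewise a limit.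

Compound 1 therefore stands at the limit of > 63000 nM in this assay, at which 3 of the 3 values shown sit, and no measured step between any two of these compounds can be drawn. Compound 4, `O=S(=O)(Nc1ccc2oc(-c3ccccc3)nc2c1)c1ccc(O)cc1`, differs from compound 1 by 4-hydroxyphenyl in place of 3-fluorophenyl on a sulfonyl sulfur. Within the data shown here, with every value shown sitting at the limit, there is no measured step on which to size the change; the expectation is for no step beyond the scatter, with compound 4 most likely again at the limit. The step from compound 1 to compound 4 is expected as a step that the limit leaves unreadable from compound 1 to compound 4. For compound 4 the expected value is 80000 nM, in the range 30000 nM to 300000 nM.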

Compound 4, half-maximal inhibitory concentration: > 63000 nM
Compound 4: only a limit was reported; the forecaster's own chance of this, stated with the estimate: 80%; the middle value does not contradict the limit.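

In this assay compound 4 gives > 63000 nM, a limit and not a number. No step can be read between compound 1 and compound 4: the limit of > 63000 nM in this assay, at which 4 of the 4 values shown sit. The compounds shown leave open which structural change, if any, would bring a measurable value in this assay.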